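Isopropyl to tert-butyl: one further methyl

The source may report more compounds than this note shows. Statements on the series, on what has been measured and on what is new or still open speak of the compounds shown alone.

In a functional assay (aorta) with Rattus norvegicus as the target (on this read-out lower numbers stand for stronger inhibition and higher numbers for weaker inhibition), compound 1 `CCCCc1cn2ccccc2c1S(=O)(=O)c1ccc(OCCCN(CCCC)CCCC)cc1` gives 284 nM and compound 2 `CCCCN(CCCC)CCCOc1ccc(S(=O)(=O)c2c(C(C)C)cn3ccccc23)cc1` gives 21.6 nM. Compound 2 therefore holds the lower of the two numbers, and so the stronger inhibition of the pair.

The next compound is compound 3 `CCCCN(CCCC)CCCOc1ccc(S(=O)(=O)c2c(C(C)(C)C)cn3ccccc23)cc1`. The change is methyl in place of hydrogen on a saturated chain carbon bound to an aromatic carbon and two saturated chain carbons, which means methyl in place of hydrogen on a saturated chain carbon bound to an aromatic carbon and two saturated chain carbons, or isopropyl to tert-butyl.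

For the measured compounds named here, only one measured step bears on this: a 13-fold lower number from compound 1 to compound 2 (1.12 log units; beyond the scatter), with isopropyl in place of butyl on an aromatic carbon. It shows that a change of group at this place can move the number by a large amount. However, it is a different change, and no measured step adds a methyl to isopropyl, so the direction remains open.

With so little evidence, the expected step in this assay is modest: a 1.4-fold higher number from compound 2 to compound 3 (0.14 log units; within the scatter). The estimate for compound 3 is 30 nM, with an expected range of 8 nM to 110 nM.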

Compound 3, half-maximal inhibitory concentration: 51.9 nM
Beside the measured number, compound 3's estimate is 1.7-fold (0.24 log units) below it; low and high end bracket the measured number.
By their numbers in this assay, from the lowest: compound 2; then compound 3; then compound 1.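

Adding the one methyl that turns isopropyl into tert-butyl gives a 2.4-fold higher number from compound 2 to compound 3 (0.38 log units; beyond the scatter) in this assay, so on this saturated chain carbon a single extra carbon is enough to move the number beyond the scatter, and the move is upward. Tert-butyl still keeps a clear lead over the straight chain, with a 5.5-fold lower number from compound 1 to compound 3 (0.74 log units; beyond the scatter), so among the three groups on this aromatic carbon both branched groups give lower numbers than butyl, and the order from the lowest number runs isopropyl, tert-butyl, butyl. Nothing available gives a reason for either step.

The compounds shown leave open whether a smaller group on this aromatic carbon, such as ethyl or cyclopropyl, would give a number lower still than that of isopropyl, or whether isopropyl already stands near the low point for this position. They also leave open whether the same order of isopropyl, tert-butyl and butyl would hold if the dibutylamine at the end of the chain gave way to another amine, such as piperidine.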